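A Benzyl Amide in Place of a Methylphenyl Amide

A few compounds are considered here, and "the series" means these few. Any claim that something is new, unique, unknown or untested is made for them only; others in the source may bear on it.

Measured compounds:
compound 1, `COc1ccc2c(=O)c(/C=C/C(=O)Nc3ccc(C)cc3)coc2c1`, > 200000 nM
compound 2, `COc1ccc2c(=O)c(/C=C/C(=O)Nc3cc(C)ccc3C)coc2c1`, > 200000 nM
compound 3, `COc1ccc(CNC(=O)/C=C/c2coc3cc(OC)ccc3c2=O)cc1`, > 200000 nM

In a functional assay on L02 cells (Homo sapiens) for inhibition, read by MTT assay, with a stated time of 48 h (on this read-out higher numbers stand for weaker inhibition and lower numbers for stronger inhibition), compound 1 gives > 200000 nM, which is a limit of the assay rather than a measured number. Compound 2 likewise gives > 200000 nM, again only a limit. Compound 3 gives > 200000 nM, also a limit. Compound 1 therefore cannot be placed among the others: it sits at the same limit as both, as the evidence the limit of > 200000 nM in this assay, at which 3 of the 3 values shown sit, records. The steps a step that the two limits leave unreadable from compound 1 to compound 2, a step that the two limits leave unreadable from compound 1 to compound 3 and a step that the two limits leave unreadable from compound 2 to compound 3 are all unreadable for the same reason, since neither end of any of them is a number.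

Compound 4, `COc1ccc2c(=O)c(/C=C/C(=O)NCc3ccccc3)coc2c1`, is the next variant. It differs from compound 1 by benzyl in place of 4-methylphenyl on an amide-type nitrogen. The steps seen so far involve changes of the same kind, a swap of the group on the amide-type nitrogen, and none of them produced a readable value. The expectation for compound 4 is therefore that it stays at the limit, with a step that the limit leaves unreadable from compound 1 to compound 4 expected to show nothing beyond the scatter. The estimated value for compound 4 in this assay is 250000 nM, with a range from 120000 nM to 600000 nM.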

Compound 4, half-maximal inhibitory concentration: > 200000 nM
Compound 4: no number, only a limit; the forecaster's own chance of this, stated with the estimate: 85%; the middle value lies beyond the limit too.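

In this assay compound 4 gives > 200000 nM, again a limit and not a number, so its steps from compound 1, compound 2 and compound 3 cannot be read. The compounds shown leave open how far apart these four lie in this assay, and whether any group on the amide-type nitrogen would give a readable number.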